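The source may hold more compounds than are shown below. What is called first, only, known or untested is meant among the compounds shown, and "the series" means these compounds.

Of the compounds shown here, two built on a shared core have been tested in an ADME assay on L02 cells (Homo sapiens) for cytotoxicity, read by MTT assay, with a stated time of 48 h; a lower number here means a stronger inhibitor, a higher number a weaker inhibitor. Compound 1 `CCN(CC)c1ccc2cc(C(=O)c3ccc(N4CCN(C(=O)CN5CCN(S(=O)(=O)c6ccc(C(F)(F)F)cc6)CC5)CC4)cc3)oc2c1` carries a trifluoromethyl on an aromatic carbon; in this assay compound 1 gives 17000 nM. Compound 2 `CCN(CC)c1ccc2cc(C(=O)c3ccc(N4CCN(C(=O)CN5CCN(S(=O)(=O)c6ccc(F)cc6)CC5)CC4)cc3)oc2c1` carries a fluoro in its place; in this assay compound 2 gives 9240 nM. Among the measured compounds shown here, the one measured step, a 1.8-fold lower number from compound 1 to compound 2 (0.26 log units; within the scatter), lies within the scatter, so these two numbers cannot be told apart, and compound 2 stands level with compound 1 rather than apart from it.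

Compound 3 `CCOC(=O)CN1CCN(CC(=O)N2CCN(c3ccc(C(=O)c4cc5ccc(N(CC)CC)cc5o4)cc3)CC2)CC1` has not yet been measured. It differs from compound 2 in a single place: (ethoxycarbonyl)methyl in place of (4-fluorophenyl)sulfonyl on an amine nitrogen in a ring. For the measured compounds named here, no measured step touches that ring nitrogen; the only step seen concerns a substituent on the aromatic ring that here leaves altogether, so it offers no direct guide, and the expectation can rest only on compound 2 itself.

Compound 3 is therefore expected to give about 12000 nM in this assay, with a range from 4000 nM to 40000 nM. The expected step is a 1.3-fold higher number from compound 2 to compound 3 (0.11 log units; within the scatter), that is, no change beyond the scatter.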

Compound 3, half-maximal inhibitory concentration: 68700 nM
Compound 3: middle estimate off by 5.7-fold (0.76 log units), on the low side; the whole stated range lies below it.
By their numbers in this assay, from the lowest: compounds 2 and 1 (each within the scatter of the next); then compound 3.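

In this assay the change on the ring nitrogen gives a 7.4-fold higher number from compound 2 to compound 3 (0.87 log units; beyond the scatter) and so lies beyond the scatter, unlike the earlier swap of trifluoromethyl for fluoro on an aromatic carbon. This shows that the group on this amine nitrogen can shift the number clearly upward, towards weaker inhibition, while the same shared core stays in place. The swap takes away the whole (4-fluorophenyl)sulfonyl group, with its six-membered aromatic ring of carbon only, and brings in the ringless (ethoxycarbonyl)methyl, but no measurement shown gives a reason for the shift.

Since the sulfonyl link and the aromatic ring leave together, the compounds shown cannot say which of the two parts goes with the lower number of compound 2, and a benzyl group, which keeps an aromatic ring without the sulfonyl, or a methylsulfonyl group, which keeps the sulfonyl without the ring, would separate them. Going by these compounds, it also remains open whether the ester itself matters, which a carboxylic acid or a simple ethyl group on the same nitrogen would address.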